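Varying the Carbonyl Substituent on a Shared Core

This account rests on a few compounds, and the source may have more. Where it says the series, first, only, none or still open, it means among the compounds named here.

Measured compounds:
compound 1, `CN(C)CC(=O)N1CCC(NS(=O)(=O)c2cc(S(=O)(=O)c3ccccc3)ccc2C(F)(F)F)CC1`: 280 nM
compound 2, `O=C(Cn1ccnc1)N1CCC(NS(=O)(=O)c2cc(S(=O)(=O)c3ccccc3)ccc2C(F)(F)F)CC1`: 230 nM
compound 3, `CN(C)C(=O)N1CCC[C@H]1C(=O)N1CCC(NS(=O)(=O)c2cc(S(=O)(=O)c3ccccc3)ccc2C(F)(F)F)CC1`: 160 nM

All three were tested in a functional assay on U2OS cells for antagonist activity at proto-oncogene Wnt-3 (Homo sapiens), read by a luciferase reporter, with a stated time of 18 h; a higher number here means that more compound is needed for the effect, a lower number that less compound is needed. Compound 2 holds the second highest of the three numbers; its nearest neighbour is compound 1, with a 1.2-fold lower number from compound 1 to compound 2 (0.09 log units; within the scatter), and its furthest is compound 3, with a 1.4-fold lower number from compound 2 to compound 3 (0.16 log units; within the scatter). Both steps change only the group on the carbonyl carbon and both stay within the scatter.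

Compound 4, `CN1CCC[C@H]1C(=O)N1CCC(NS(=O)(=O)c2cc(S(=O)(=O)c3ccccc3)ccc2C(F)(F)F)CC1`, is not yet measured. It differs from compound 2 by 1-methylpyrrolidin-2-yl in place of (1H-imidazol-1-yl)methyl on a carbonyl carbon. Since every change at this position seen so far, a 1.2-fold lower number from compound 1 to compound 2 (0.09 log units; within the scatter) and a 1.4-fold lower number from compound 2 to compound 3 (0.16 log units; within the scatter), stayed within the scatter, no step beyond the scatter is expected here either. The expected step is a 1.2-fold lower number from compound 2 to compound 4 (0.06 log units; within the scatter). Compound 4 is therefore estimated at 200 nM, with a range from 100 nM to 400 nM.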

Compound 4, half-maximal effective concentration: 230 nM
Compound 4: the middle estimate sits 1.2-fold (0.06 log units) below what was measured; low and high end bracket the measured number.
By their numbers in this assay, from the lowest: compounds 3, 2, 4 and 1 (each within the scatter of the next).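

Among these compounds, the aromatic ring of (1H-imidazol-1-yl)methyl is not required on this carbonyl carbon: the non-aromatic 1-methylpyrrolidin-2-yl, with one hydrogen-bond acceptor fewer and a defined stereocentre, takes its place (no change at the digits printed from compound 2 to compound 4 (within the scatter)). Exchanging dimethylcarbamoyl for methyl on the ring nitrogen (a 1.4-fold higher number from compound 3 to compound 4 (0.16 log units; within the scatter)) and (dimethylamino)methyl for the ring (a 1.2-fold lower number from compound 1 to compound 4 (0.09 log units; within the scatter)) also stays within the scatter. Nothing measured here explains this flat response. Going by these compounds, whether a carboxylic acid, a primary amine or a longer chain on this carbonyl carbon would move the number beyond the scatter remains open.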